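Series notes: benzylsulfanyl substitution toward compound 4

The compounds below may be only part of what the source reports. "The series", "measured", "known", "first", "only" and "open" are said of these compounds alone.

Measured compounds:
compound 1 `Cc1nsc2c1ncn2[C@H]1C[C@H](O)[C@@H](CO)O1`; in a functional assay on L1210 cells (Mus musculus) for antiproliferative activity (a lower number here means a stronger inhibitor, a higher number a weaker inhibitor), compound 1 gives > 100000 nM, a limit of the assay rather than a number.
compound 2 `Cc1nsc2c1nc(SCc1ccccc1)n2[C@H]1C[C@H](O)[C@@H](CO)O1`; here compound 2 gives > 100000 nM, again a limit.
compound 3 `Cc1nsc2c1ncn2[C@@H]1O[C@H](CO)[C@@H](O)[C@@H]1O`; here compound 3 gives > 100000 nM, also a limit.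

Compound 3 thus stands at the limit, as do all measured compounds (the limit of > 100000 nM in this assay, at which 3 of the 3 values shown sit). Compound 4 `Cc1nsc2c1nc(SCc1ccccc1)n2[C@@H]1O[C@H](CO)[C@@H](O)[C@@H]1O` differs from compound 3 by benzylsulfanyl in place of hydrogen on an aromatic carbon. The same change on the core of compound 1 gave a step that the two limits leave unreadable from compound 1 to compound 2, and the hydroxy step gave a step that the two limits leave unreadable from compound 1 to compound 3, so neither size is readable. Among the compounds with values here, no measured step supports an expectation of change beyond the scatter. Compound 4 is expected to stay at the limit, with an estimated step of a number no higher from compound 3 to compound 4 (the limit leaves the size open). The estimate for compound 4 is 100000 nM, between 30000 nM and 300000 nM.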

Compound 4, half-maximal inhibitory concentration: > 100000 nM
Compound 4: no number, only a limit; the forecaster's own chance of this, stated with the estimate: 85%; the middle value sits exactly at the limit.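

In this assay compound 4 gives > 100000 nM, a limit, so neither its step from compound 2 nor its step from compound 3 can be read. The compounds shown leave open whether benzylsulfanyl or hydroxy changes the inhibition at all.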